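Compound 3: bromo in place of methyl

A few compounds are considered here, and "the series" means these few. Any claim that something is new, unique, unknown or untested is made for them only; others in the source may bear on it.

In a functional assay on MGC-803 cells (Homo sapiens) for inhibition, read by MTT assay, with a stated time of 48 h (on this read-out higher numbers stand for weaker inhibition and lower numbers for stronger inhibition), compound 1 `C/C=C/C=C/C(=O)N(Cc1ccc(OC)c(O)c1)c1cc(OC)c(OC)c(OC)c1` gives 140 nM and compound 2 `CC/C=C/C(=O)N(Cc1ccc(OC)c(O)c1)c1cc(OC)c(OC)c(OC)c1` gives 58 nM, the lower of the two numbers. Compound 3 `COc1ccc(CN(C(=O)/C=C/CBr)c2cc(OC)c(OC)c(OC)c2)cc1O` is not yet measured. It differs from compound 2 by bromo in place of methyl on a saturated chain carbon bound to a double-bonded chain carbon, with bromo in place of methyl on a saturated chain carbon bound to a double-bonded chain carbon, so that ethyl becomes bromomethyl.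

Among the compounds with values here, only one measured step bears on this change, and only indirectly: a 2.4-fold lower number from compound 1 to compound 2 (0.38 log units; beyond the scatter), a modest step from ethyl in place of prop-1-en-1-yl. Within the data shown here, no measured compound carries bromo, so the data give no firm direction. The expected result is a 1.2-fold lower number from compound 2 to compound 3 (0.06 log units; within the scatter), and a modest step either way would not be surprising. For compound 3 the estimate is 50 nM, with an expected range of 15 nM to 170 nM.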

Compound 3, half-maximal inhibitory concentration: 71 nM
Compound 3: middle estimate off by 1.4-fold (0.15 log units), on the low side, and the stated range covers the measured number.
By their numbers in this assay, from the lowest: compounds 2, 3 and 1 (each within the scatter of the next, the first and the last beyond it).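

In this assay, the swap of methyl for bromo on the saturated chain carbon gives a 1.2-fold higher number from compound 2 to compound 3 (0.09 log units; within the scatter) and so does not separate the two groups at this position, a first sign that this chain end accepts a heavy atom other than carbon without a step beyond the scatter. The comparison with the longer unsaturated chain gives a 2.0-fold lower number from compound 1 to compound 3 (0.29 log units; within the scatter) and also stays within the scatter, whereas ethyl against prop-1-en-1-yl gave a 2.4-fold lower number from compound 1 to compound 2 (0.38 log units; beyond the scatter) and lay beyond it. No measurement available here accounts for these numbers.

Going by these compounds, how chloro, hydroxy or an amine on this saturated chain carbon would read stays open. So does the reading of a longer chain carrying bromo at its end, and of a carboxylic acid in that place.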